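This account rests on a few compounds, and the source may have more. Where it says the series, first, only, none or still open, it means among the compounds named here.

Measured compounds in the series:

compound 1, `CCCNS(=O)(=O)c1ccc(Nc2ncc3c(n2)N(c2ccn(C)n2)C(CC)C(=O)N3C)cc1`: 2670 nM
compound 2, `CCCCNS(=O)(=O)c1ccc(Nc2ncc3c(n2)N(c2ccn(C)n2)C(CC)C(=O)N3C)cc1`: 4320 nM
compound 3, `CCCNC(=O)c1ccc2c(ccn2-c2ncc3c(n2)N(c2ccn(C)n2)C(CC)C(=O)N3C)c1`: 6160 nM

All three values come from a functional assay on HeLa cells (Homo sapiens) for antiproliferative activity, read by CCK-8 assay, with a stated time of 72 h; a higher number here means a weaker inhibitor of growth, a lower number a stronger inhibitor of growth. Compounds 1 and 2 share a core and differ only by methyl in place of hydrogen on a saturated chain carbon, three bonds along the chain from a sulfonamide nitrogen; the step is a 1.6-fold higher number from compound 1 to compound 2 (0.21 log units; within the scatter). Among the compounds with values here, compound 3 carries a different core; the difference between the two cores is not broken down here, and the values of compound 1 and compound 3 are the only pair among the three that lie beyond the scatter.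

Compound 4, `CCCCNC(=O)c1ccc2c(ccn2-c2ncc3c(n2)N(c2ccn(C)n2)C(CC)C(=O)N3C)c1`, is not yet measured. It differs from compound 3 by methyl in place of hydrogen on a saturated chain carbon, three bonds along the chain from an amide-type nitrogen. This is the same kind of change as that from compound 1 to compound 2, not the same: there the place is three bonds along the chain from a sulfonamide nitrogen, here three bonds along the chain from an amide-type nitrogen. Within the data shown here, only one such step is known in this assay, so the expectation rests on a single precedent. The step from compound 3 to compound 4 is expected to be about a 1.4-fold higher number from compound 3 to compound 4 (0.14 log units; within the scatter), because the comparable step is a 1.6-fold higher number from compound 1 to compound 2 (0.21 log units; within the scatter) in this assay. Compound 4 is therefore estimated at 8500 nM, with a range of 4500 nM to 16000 nM in this assay.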

Compound 4, concentration for 50% growth inhibition: 4260 nM
The estimate for compound 4 lay 2.0-fold (0.30 log units) above the measured number, and the stated range ends above it.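

In this assay the change from propyl to butyl on the core of compound 3 gives a 1.4-fold lower number from compound 3 to compound 4 (0.16 log units; within the scatter) and so stays small on this core as well. Set beside the step on the core of compound 1, the two steps carry opposite signs, yet the gap between them does not exceed what two such steps can show by scatter alone: the same change on two cores in this assay, a 1.6-fold higher number (0.21 log units; within the scatter) from compound 1 to compound 2 and a 1.4-fold lower number (0.16 log units; within the scatter) from compound 3 to compound 4, 2.3-fold (0.37 log units) apart, within the scatter of two such steps. So far the change has been carried from one core to the other without a step beyond the scatter on either, but a single pair on each core shows neither a real dependence on the core nor a shared effect of the change.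

The compounds shown leave open whether a longer chain such as pentyl, or a chain ending in an amine or a carboxylic acid, would give a step beyond the scatter on either core. From the compounds shown here alone, whether a shorter chain such as ethyl would behave alike on both cores also remains open.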